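Fluoro in Place of Methyl on a Shared Core

The source may hold more compounds than are shown below. What is called first, only, known or untested is meant among the compounds shown, and "the series" means these compounds.

Compound 2 `Cc1ccc2nc(C(=O)Nc3c(F)cc(-c4cccc(F)c4)cc3F)c(C)c(C(=O)O)c2c1` stands highest of the two numbers in a functional assay on Hep 3B2 cells (Homo sapiens) for antiproliferative activity, read by MTT assay, with a stated time of 24 h, tested at 0.41 ug/mL (on this read-out higher numbers stand for a stronger effect at the one concentration tested and lower numbers for a weaker effect), with 15.2%. Among the measured compounds shown here, its only neighbour, compound 1 `Cc1ccc2nc(C(=O)Nc3c(F)cc(-c4cccc(F)c4)cc3F)c(C)c(O)c2c1`, gives 5.25%, and the step of a number 10 percentage points higher from compound 1 to compound 2 (within the scatter) is within the scatter. Compound 3 `Cc1c(C(=O)Nc2c(F)cc(-c3cccc(F)c3)cc2F)nc2ccc(F)cc2c1C(=O)O` differs from compound 2 by fluoro in place of methyl on an aromatic carbon. For the measured compounds named here, no measured step touches this position, and the single known step was within the scatter, so no shift beyond the scatter is expected: the step of a number 0.2 percentage points lower from compound 2 to compound 3 (within the scatter) is estimated to be small. Compound 3 is therefore expected to give about 15%, in the range 3% to 28%.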

Compound 3, a percentage reported as inhibition, at one concentration (the size of the read-out at that concentration, not a potency): 1.06%
Compound 3: middle estimate off by 13.9 percentage points, on the high side, and the stated range ends above it.
By their numbers in this assay, from the lowest: compounds 3, 1 and 2 (each within the scatter of the next, the first and the last beyond it).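

Placing fluoro in place of methyl on this aromatic carbon, meta to a fused ring and para to a fused ring, gives the first step beyond the scatter in this assay: a number 14.1 percentage points lower from compound 2 to compound 3 (beyond the scatter). The earlier step at the other position, a number 10 percentage points higher from compound 1 to compound 2 (within the scatter), stayed within it, so this methyl position is the one that so far responds to a change. No measurement at hand accounts for this result. On these data alone, whether chloro, methoxy or an amine on this carbon would keep the number of compound 2 remains open, as does whether methyl itself matters or any replacement would lower the number.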